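A Piperidinyl Swap on Two Cytotoxicity-Inactive Amides

The source may report more compounds than this note shows. Statements on the series, on what has been measured and on what is new or still open speak of the compounds shown alone.

Compound 1 `CCCCN1CCC(C(=O)Nc2ccc(CNc3nc(N(C)C)nc4cc(C)ccc34)cc2)CC1` reaches only a limit in a functional assay on SV5A8 cells (Homo sapiens) for cytotoxicity; a lower number here means a stronger inhibitor, a higher number a weaker inhibitor: compound 1 gives > 10500 nM, a limit rather than a number. Compound 2 `Cc1ccc2c(NCc3ccc(NC(=O)C4CCN(Cc5ccco5)CC4)cc3)nc(N(C)C)nc2c1` likewise shows only a limit, > 20000 nM, in this assay. The step that the two limits leave unreadable from compound 1 to compound 2 therefore cannot be read. Compound 3 `Cc1ccc2c(NCc3ccc(NC(=O)C4CCN(CC5CCNCC5)CC4)cc3)nc(N(C)C)nc2c1` differs from compound 2 by piperidin-4-yl in place of furan-2-yl on a saturated chain carbon bound to an amine nitrogen in a ring. Going by the values given here, the one measured step concerns a different exchange at the same place and has no readable size, so no change beyond the scatter is expected in either direction. Compound 3 is expected near 20000 nM, between 5000 nM and 60000 nM, an expected step of a number no higher from compound 2 to compound 3 (the limit leaves the size open).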

Compound 3, half-maximal inhibitory concentration: > 8070 nM
Compound 3: only a limit was reported; the forecaster's own chance of this, stated with the estimate: 80%; the middle value is on the limit's open side.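

Going by these compounds alone, compound 1, compound 2 and compound 3 each give only a limit in this assay, so no step among them can be read. As far as these compounds go, whether any group at this place gives a measurable cytotoxicity value stays open.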